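Phenolic hydroxyl replaced by a benzyl ether: compound 4

The source may hold more compounds than are shown below. What is called first, only, known or untested is meant among the compounds shown, and "the series" means these compounds.

Three close relatives share one core and have been tested in a functional assay on cells (T-cell, Mus musculus, strain BALB/c) for inhibition, read by MTT assay, with stated times of 24 h and 72 h; on this read-out higher numbers stand for weaker inhibition and lower numbers for stronger inhibition. Compound 1 `COc1cc(-c2nnc(SCc3ccccc3Br)o2)ccc1O` gives 17800 nM. Compound 2 `COc1cc(-c2nnc(SCc3ccccc3Cl)o2)ccc1O` gives 8430 nM, and compound 3 `COc1cccc(CSc2nnc(-c3ccc(O)c(OC)c3)o2)c1` gives 7410 nM. Among these three numbers compound 2 stands second highest: its nearest neighbour is compound 3, within the usual scatter, while compound 1 is further away, as the step of a 2.1-fold lower number from compound 1 to compound 2 (0.32 log units; beyond the scatter) shows. The change from compound 2 to compound 3 is a 1.1-fold lower number from compound 2 to compound 3 (0.06 log units; within the scatter), so those two compounds cannot be told apart on this read-out.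

Compound 4 `COc1cc(-c2nnc(SCc3ccccc3Cl)o2)ccc1OCc1ccccc1Cl` differs from compound 2 by 2-chlorobenzyl in place of hydrogen on an oxygen on an aromatic ring, which amounts to hydroxy becoming (2-chlorobenzyl)oxy. Among the compounds with values here, none of the measured steps touches this oxygen; every one of them alters the group carried by the sulfur. Within the data shown here, no measured step therefore bears directly on this change, and there is no ground for a confident direction. The expected step is a 1.1-fold lower number from compound 2 to compound 4 (0.02 log units; within the scatter), with a wide margin. Compound 4 is estimated at 8000 nM, expected to lie between 2500 nM and 25000 nM.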

Compound 4, half-maximal inhibitory concentration: 10600 nM
For compound 4 the middle estimate is 1.3-fold (0.12 log units) below the measured one, within the range that was stated.
By their numbers in this assay, from the lowest: compounds 3, 2, 4 and 1 (each within the scatter of the next, the first and the last beyond it).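

Within the data shown here, this is the first change at the oxygen on the aromatic ring; all earlier steps altered the group carried by the sulfur. In this assay, hydroxy becoming (2-chlorobenzyl)oxy gives a small step (a 1.3-fold higher number from compound 2 to compound 4 (0.10 log units; within the scatter)), so compound 2 and compound 4 cannot be told apart, even though the hydrogen is replaced by a group of 8 heavy atoms with its own aromatic ring. For this pair, then, a free hydroxy is not needed to keep the read-out at this level, and no measurement here offers an explanation.

Going by these compounds, whether other groups on this oxygen, such as methyl, a longer alkyl chain or a chain ending in an amine or a carboxylic acid, would read the same remains open. So does whether 2-chlorobenzyl on this oxygen would behave alike alongside the 3-methoxyphenyl group of compound 3.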